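Methoxy to hydroxy changes across three measured compounds

This account rests on a few compounds, and the source may have more. Where it says the series, first, only, none or still open, it means among the compounds named here.

So far, compound 1, compound 2 and compound 3 have been measured in an assay for inhibition of solute carrier family 22 member 12 (Homo sapiens), read by scintillation counting, with a stated time of 60 min, tested at 50 uM; a lower number here means less inhibition, a higher number more inhibition at the concentration tested (going by the name of the read-out):

compound 1 `CCc1cc2c(C(=O)c3ccc(OC)cc3)cc(OC)cc2o1` gives 1.5%
compound 2 `CCc1cc2c(C(=O)c3ccc(OC)cc3)c(O)ccc2o1` gives 28.7%
compound 3 `CCc1cc2c(C(=O)c3ccc(O)cc3)c(O)ccc2o1` gives 51.5%

Compound 1 stands lowest of the three; compound 2 lies above it beyond the scatter, and compound 3 further above still. The difference between the core of compound 1 and the core of compound 2 is not broken down here.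

Within the measured set one single-point change is documented: hydrogen in place of methyl on an oxygen on an aromatic ring. This change carries a number 22.8 percentage points higher from compound 2 to compound 3 (beyond the scatter), a modest step in this assay, beyond the scatter.

The unmeasured compound 4 `CCc1cc2c(C(=O)c3ccc(O)cc3)cc(OC)cc2o1` is related to compound 1 by the same change, (hydrogen in place of methyl on an oxygen on an aromatic ring), and the surroundings of the place are the same as in the step from compound 2 to compound 3. The expectation for compound 4 therefore rests on that earlier step: a similar rise in this assay is expected, with the reservation that compound 1 starts from a far lower number than compound 2 and the change has been seen only once, so the size of the step in a different core cannot be assumed to carry over fully. Compound 4 is expected to give 18% in this assay, with a range from 3% to 38%. This estimate means a step of a number 16.5 percentage points higher from compound 1 to compound 4 (beyond the scatter), comparable to, but allowed to fall short of, the step observed from compound 2 to compound 3.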

Compound 4, a percentage reported as inhibition, at one concentration (the size of the read-out at that concentration, not a potency): 62.4%
Compound 4: middle estimate off by 44.4 percentage points, on the low side; the whole stated range lies below it.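

Replacing methyl by hydrogen on an oxygen on an aromatic ring raises the number on both cores, and in this assay the new step is a number 60.9 percentage points higher from compound 1 to compound 4 (beyond the scatter). The direction of the change therefore carries from one core to the other in these two pairs, but its size does not: the same change on two cores in this assay, a number 22.8 percentage points higher (beyond the scatter) from compound 2 to compound 3 and a number 60.9 percentage points higher (beyond the scatter) from compound 1 to compound 4, 38.1 percentage points apart, beyond the scatter of two such steps. This shows that the core matters for how much the methoxy to hydroxy change is worth here, and a step measured on one core is a poor guide to its size on another, but two pairs do not show which difference between the cores sets the size, nor do they give a rule for any further core.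

The compounds shown hold only methoxy and hydroxy at the place of this change, leaving open whether a longer chain on the oxygen, such as ethoxy, or a carboxylic acid or an amine in place of the hydroxy would keep the higher numbers. Also open, as far as these compounds go, is whether the ethyl group common to all four compounds can give way to a propyl chain or a simple methyl without altering the size of the methoxy to hydroxy step on either core.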